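Swapping a Ketone for an Alkene on the Core

The source may report more compounds than this note shows. Statements on the series, on what has been measured and on what is new or still open speak of the compounds shown alone.

Three compounds have been measured in a functional assay on the whole organism (Abdomen, strain Swiss) for inhibition, with Mus musculus as the target, with stated times of 30 min, 10 min and 5 min, at a dose of 20 mg/kg by the oral route; on this read-out lower numbers stand for a weaker effect and higher numbers for a stronger effect at the one dose given:

compound 1 `CCc1nn(CCCN2CCN(c3ccc(C)cc3)CC2)c(=O)c(N)c1C(C)=O` gives 42%
compound 2 `CCC(=O)c1c(C)nn(CCCN2CCN(c3ccc(C)cc3)CC2)c(=O)c1N` gives 40%
compound 3 `C=Cc1c(CC)nn(CCCN2CCN(c3ccc(C)cc3)CC2)c(=O)c1N` gives 0%

Compound 2 stands second highest of these three numbers. Its value lies close to that of compound 1, within the usual scatter, so no order between the two can be claimed, while compound 3 lies far lower, beyond the scatter.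

Compound 4 `C/C=C/c1c(C)nn(CCCN2CCN(c3ccc(C)cc3)CC2)c(=O)c1N` has not yet been measured in this assay. It differs from compound 2 by prop-1-en-1-yl in place of propanoyl on an aromatic carbon. Among the measured compounds shown here, one measured step bears directly on this change: a number 42 percentage points lower from compound 1 to compound 3 (beyond the scatter), where, in the same way, a group with a carbonyl gave way to a plain double bond on the same aromatic carbon. Because a number 42 percentage points lower from compound 1 to compound 3 (beyond the scatter) was large and downward, a drop of similar size is expected here, a number 35 percentage points lower from compound 2 to compound 4 (beyond the scatter). Compound 4 is therefore estimated at 5%, with a range from 0% to 22%.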

Compound 4, a percentage reported as inhibition, in the whole organism at one dose (the size of the read-out at that dose, not a potency): 44%
Beside the measured number, compound 4's estimate is 39 percentage points below it, outside the stated range (above it).
By their numbers in this assay, from the lowest: compound 3; then compounds 2, 1 and 4 (each within the scatter of the next).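

In this assay putting prop-1-en-1-yl in place of propanoyl on this aromatic carbon gives a number 4 percentage points higher from compound 2 to compound 4 (within the scatter) and so shows that a carbonyl group here can give way to a plain double bond with no readable change. This swap takes away the one hydrogen-bond acceptor of propanoyl and one heavy atom, yet the read-out holds, whereas the earlier swap of acetyl for vinyl on the same carbon gave a number 42 percentage points lower from compound 1 to compound 3 (beyond the scatter) as its step. Losing the carbonyl at this position therefore does not by itself bring a drop, and compound 3 stands as the one case that does fall.

Nothing shown explains why the two steps part ways. From the compounds shown here alone, how an amine, a carboxylic acid or a longer chain on this carbon would fare also stays open.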